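Nitro for Cyano on a Shared Anilide Scaffold

This account rests on a few compounds, and the source may have more. Where it says the series, first, only, none or still open, it means among the compounds named here.

Compound 1 `CC(O)(CSc1cc(C(F)(F)F)cc(C(F)(F)F)c1)C(=O)Nc1ccc(C#N)cc1C(F)(F)F` and compound 2 `CC(O)(CSc1cc(C(F)(F)F)cc(C(F)(F)F)c1)C(=O)Nc1ccc([N+](=O)[O-])cc1C(F)(F)F` share one core; in a functional assay on DU-145 cells (Homo sapiens) for antiproliferative activity, read by fluorescence and propidium iodide staining, with a stated time of 96 h (on this read-out lower numbers stand for stronger inhibition and higher numbers for weaker inhibition), compound 1 gives 9090 nM and compound 2 gives 3380 nM. The change between them, (nitro in place of cyano on an aromatic carbon), made a step of a 2.7-fold lower number from compound 1 to compound 2 (0.43 log units; beyond the scatter). Compound 3 `CC(O)(COc1cc(C(F)(F)F)cc(C(F)(F)F)c1)C(=O)Nc1ccc(C#N)cc1C(F)(F)F` has a core that differs from that of compound 1 in a way not broken down here; in this assay compound 3 gives 8050 nM. Compound 4 `CC(O)(COc1cc(C(F)(F)F)cc(C(F)(F)F)c1)C(=O)Nc1ccc([N+](=O)[O-])cc1C(F)(F)F` is not yet measured and differs from compound 3 by nitro in place of cyano on an aromatic carbon, the same change as before. Because the earlier step was a 2.7-fold lower number from compound 1 to compound 2 (0.43 log units; beyond the scatter), a similar step, a 2.5-fold lower number from compound 3 to compound 4 (0.40 log units; beyond the scatter), is expected here, which rests on a single precedent only. Compound 4 is estimated at 3200 nM in this assay, expected between 1500 nM and 7000 nM.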

Compound 4, half-maximal inhibitory concentration: 11600 nM
Beside the measured number, compound 4's estimate is 3.6-fold (0.56 log units) below it, outside the stated range (above it).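

In this assay putting nitro in place of cyano gives a 1.4-fold higher number from compound 3 to compound 4 (0.16 log units; within the scatter) and so does not repeat the clear drop seen on the first core, and the two steps differ: the same change on two cores in this assay, a 2.7-fold lower number (0.43 log units; beyond the scatter) from compound 1 to compound 2 and a 1.4-fold higher number (0.16 log units; within the scatter) from compound 3 to compound 4, 3.9-fold (0.59 log units) apart, beyond the scatter of two such steps. This shows that, across these two pairs, the result of the change depends on the core that carries it, so a step measured on one core is a poor guide to the next. It does not show what in the cores is responsible, or which of the two steps is the more typical.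

The compounds shown leave open how either core responds to other groups in the same place, such as an amine or a carboxylic acid. They also leave open how a third core would respond to the same change.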